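The compounds below may be only part of what the source reports. "The series", "measured", "known", "first", "only" and "open" are said of these compounds alone.

Compound 1, `O=C(CCc1ccc(NC(=O)Nc2ccc(Cl)c(C(F)(F)F)c2)cc1)NC1CCC1`, in a functional assay on A-375 cells (Homo sapiens) for inhibition, read by MTT assay, with a stated time of 120 h (a higher number here means a weaker inhibitor, a lower number a stronger inhibitor), gives > 50000 nM, which is a limit of the assay rather than a number.
Compound 2, `CNC(=O)c1cccc(-c2ccc(NC(=O)Nc3ccc(Cl)c(C(F)(F)F)c3)cc2)c1`, gives 46500 nM.
Compound 3, `CNC(=O)CCc1ccc(NC(=O)Nc2ccc(Cl)c(C(F)(F)F)c2)cc1`, gives 25200 nM.

Compound 3 shows the lowest of the two numbers, but its nearest neighbour, compound 2, sits only a 1.8-fold lower number from compound 2 to compound 3 (0.27 log units; within the scatter) away, so the two cannot be ranked. Compound 4, `CC(NC(=O)CCc1ccc(NC(=O)Nc2ccc(Cl)c(C(F)(F)F)c2)cc1)c1ccccc1`, differs from compound 3 by 1-phenylethyl in place of methyl on an amide-type nitrogen. Within the data shown here, the only measured step at the same amide nitrogen is an at least 1.9-fold lower number from compound 1 to compound 3 (0.29 log units; that floor lies within the scatter), where the smaller group went with the lower number and the larger one reached the limit (the limit of > 50000 nM in this assay, at which 1 of the 3 values shown sits). Placing a larger group there again is therefore expected to raise the number, by roughly a 1.8-fold higher number from compound 3 to compound 4 (0.25 log units; within the scatter). Compound 4 is estimated at 45000 nM, with a likely range from 15000 nM to 130000 nM.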

Compound 4, half-maximal inhibitory concentration: > 50000 nM
Compound 4 gave a limit, no number; the forecaster's own chance of this, stated with the estimate: 45%; middle value at least 1.1-fold (0.04 log units) away from the limit.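

In this assay the change from methyl to 1-phenylethyl on the amide-type nitrogen gives an at least 1.9-fold higher number from compound 3 to compound 4 (0.29 log units; that floor lies within the scatter) and no more exact size. Compound 4, like compound 1, ends at a limit of the assay and not at a number, so the step between these two cannot be read. A second group larger than methyl, this one carrying an aromatic ring, now sits at the same limit on this nitrogen: the limit of > 50000 nM in this assay, at which 2 of the 4 values shown sit.

Still open, going by these compounds, is whether ethyl on this nitrogen, or an amine or a carboxylic acid at the end of the chain, would give a clearly lower number.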